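Allyl replaces prenyl on the chromane-type ether of compound 2

This account rests on a few compounds, and the source may have more. Where it says the series, first, only, none or still open, it means among the compounds named here.

Of the compounds shown here, two share one core and have been tested in a functional assay on MCF7 cells (Homo sapiens), tested at 7.5 uM; a lower number here means a stronger effect, a higher number a weaker effect of the compound at the concentration tested. Compound 1, `C=CCOc1c(C)c(C)c2c(c1C)CCC(C)(COc1ccc(/C=C3\SC(=O)NC3=O)cc1OC)O2`, gives 1%. Compound 2, `CC(C)=CCOc1c(C)c(C)c2c(c1C)CCC(C)(COc1ccc(/C=C3\SC(=O)NC3=O)cc1C)O2`, gives 27%, the higher of the two numbers, and its gap to compound 1 lies beyond the scatter. The two differ in more than one place, so those two values alone do not tell which part of the difference carries the gap.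

Compound 3, `C=CCOc1c(C)c(C)c2c(c1C)CCC(C)(COc1ccc(/C=C3\SC(=O)NC3=O)cc1C)O2`, has not yet been measured. It differs from compound 2 in one place: vinyl in place of 2-methylprop-1-en-1-yl on a saturated chain carbon bound to an oxygen on an aromatic ring. For the measured compounds named here, the group that enters is the one carried by compound 1 at that spot, while the rest of compound 3 stays as in compound 2.

Going by the values given here, no measured pair shows this change on its own, so its effect is not known. A step from compound 2 to compound 3 of modest size toward the value of compound 1 is expected, as a number 12 percentage points lower from compound 2 to compound 3 (beyond the scatter), though a step within the scatter cannot be ruled out. The estimate for compound 3 in this assay is 15%, with a range from 2% to 35%.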

Compound 3, a percentage reported as activity, at one concentration (the size of the read-out at that concentration, not a potency): 8%
Beside the measured number, compound 3's estimate is 7 percentage points above it, and the stated range covers the measured number.
By their numbers in this assay, from the lowest: compounds 1 and 3 (each within the scatter of the next); then compound 2.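

Taken on its own, the change to vinyl in place of 2-methylprop-1-en-1-yl on a saturated chain carbon bound to an oxygen on an aromatic ring gives a number 19 percentage points lower from compound 2 to compound 3 (beyond the scatter) in this assay, so this change alone moves the read-out by more than the usual scatter. The second difference between compound 1 and compound 2 can now be read too: methyl in place of methoxy on an aromatic carbon gives a number 7 percentage points higher from compound 1 to compound 3 (within the scatter), so with allyl on the oxygen this aromatic swap shows no clear effect, and the larger part of the original gap goes with the allyl for 3-methylbut-2-en-1-yl change. Nothing available here offers a reason for the size or direction of either step.

The compounds shown have only allyl and 3-methylbut-2-en-1-yl on that oxygen, so it remains open how a saturated propyl group, a longer chain or a chain ending in an amine or a carboxylic acid would behave. On these data alone, it is also open whether methoxy in place of methyl would leave the read-out unchanged when 3-methylbut-2-en-1-yl is on the oxygen.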